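From Acetyl to tert-Butyl: Expecting a Partial Recovery

The compounds below may be only part of what the source reports. "The series", "measured", "known", "first", "only" and "open" are said of these compounds alone.

Measured in a functional assay on B16-F0 cells (Mus musculus) for inhibition, read by CCK-8 assay, with a stated time of 48 h; on this read-out lower numbers stand for stronger inhibition and higher numbers for weaker inhibition:
- Compound 1 `COc1cc(-c2ccnc3cc(-c4ccc(C)cc4)nn23)cc(OC)c1OC`: 21 nM
- Compound 2 `COc1cc(-c2ccnc3cc(-c4cccc(C)c4)nn23)cc(OC)c1OC`: 2220 nM
- Compound 3 `COc1cc(-c2ccnc3cc(-c4ccc(C(C)=O)cc4)nn23)cc(OC)c1OC`: 3930 nM

Compound 3 stands far from the best value here, and its nearest neighbour shows no real gap: a 1.8-fold higher number from compound 2 to compound 3 (0.25 log units; within the scatter). The unmeasured compound 4 `COc1cc(-c2ccnc3cc(-c4ccc(C(C)(C)C)cc4)nn23)cc(OC)c1OC` carries tert-butyl in place of acetyl on an aromatic carbon.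

The most relevant evidence is the change at this same spot, acetyl in place of methyl: a 190-fold higher number from compound 1 to compound 3 (2.27 log units; beyond the scatter). Moving the methyl of compound 1 also mattered: a 110-fold higher number from compound 1 to compound 2 (2.02 log units; beyond the scatter). Like that methyl in compound 1, tert-butyl is all carbon, and it keeps the position of the 4-methylphenyl group, so part of the large loss may return. For the measured compounds named here, no measured compound carries tert-butyl, so the size of any recovery remains uncertain. A drop in the number is expected, estimated as an 11-fold lower number from compound 3 to compound 4 (1.05 log units; beyond the scatter). For compound 4 the expected value is 350 nM, with an estimated range of 40 nM to 3000 nM.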

Compound 4, half-maximal inhibitory concentration: > 10000 nM
Compound 4 ended at the assay's limit (the forecaster's own chance of this, stated with the estimate: 3%); middle value at least 28-fold (1.45 log units) away from the limit.
By their numbers in this assay, from the lowest: compound 1; then compounds 2 and 3 (each within the scatter of the next). At a limit, above all of these: compound 4.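

The result for compound 4 is a limit of the assay, not a number: the limit of > 10000 nM in this assay, at which 1 of the 4 values shown sits. Even so, it shows that an all-carbon group at this spot does not by itself restore the strength seen with methyl, since tert-butyl in place of acetyl gives an at least 2.5-fold higher number from compound 3 to compound 4 (0.40 log units; beyond the scatter), and the comparison with the shifted methyl gives an at least 4.5-fold higher number from compound 2 to compound 4 (0.65 log units; beyond the scatter). Exchanging methyl for tert-butyl on the same aromatic carbon gives an at least 470-fold higher number from compound 1 to compound 4 (2.67 log units; beyond the scatter), so replacing one carbon group with another here is enough to span the whole range shown.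

The compounds shown leave open how an ethyl or isopropyl group would behave at this position, and whether a methoxy group or an amine could match methyl. Going by these compounds, how far the true value of compound 4 lies past its limit also remains unknown.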